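Phenyl for Chloro: Expecting Compound 4

A few compounds are considered here, and "the series" means these few. Any claim that something is new, unique, unknown or untested is made for them only; others in the source may bear on it.

In a functional assay on SW480 cells (Homo sapiens) for inhibition, read by MTT assay, with a stated time of 72 h (on this read-out higher numbers stand for weaker inhibition of growth and lower numbers for stronger inhibition of growth), compound 1 `O=C(NCc1ccc(-c2ccccc2)cc1)c1ccc[nH]1` gives 4300 nM. Compound 2 `O=C(NCc1ccccc1)c1cc(Br)c(Br)[nH]1` reaches only a limit of the assay rather than a number, > 50000 nM. Compound 3 `O=C(NCc1ccc(Cl)cc1)c1cc(Br)c(Br)[nH]1` gives 36000 nM, the highest of the two numbers shown, with compound 1 far lower. Among the measured compounds shown here, the only measured step, an at least 1.3-fold lower number from compound 2 to compound 3 (0.14 log units; that floor lies within the scatter), is small and not securely beyond the scatter. Compound 4 `O=C(NCc1ccc(-c2ccccc2)cc1)c1cc(Br)c(Br)[nH]1` differs from compound 3 by phenyl in place of chloro on an aromatic carbon. For the measured compounds named here, no measured step tests that exchange among compounds sharing the core of compound 3, so guidance is thin; compound 1, carrying the same phenyl on a core without the two bromines, gives 4300 nM. The step of a 3.6-fold lower number from compound 3 to compound 4 (0.56 log units; beyond the scatter) is therefore expected to lower the number moderately. Compound 4 is estimated at 10000 nM, within 2500 nM to 40000 nM.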

Compound 4, concentration for 50% growth inhibition: 2400 nM
For compound 4 the middle estimate is 4.2-fold (0.62 log units) above the measured one; the whole stated range lies above it.
By their numbers in this assay, from the lowest: compounds 4 and 1 (each within the scatter of the next); then compound 3. At a limit, above all of these: compound 2.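

In this assay, phenyl in place of chloro gives a 15-fold lower number from compound 3 to compound 4 (1.18 log units; beyond the scatter) so this position, para to a large group, clearly tolerates the larger ring. With phenyl present, the two bromines make no readable difference, as 4,5-dibromo-1H-pyrrol-2-yl in place of 1H-pyrrol-2-yl gives a 1.8-fold lower number from compound 1 to compound 4 (0.25 log units; within the scatter) and stays within the scatter. Phenyl in place of hydrogen gives an at least 20-fold lower number from compound 2 to compound 4 (1.31 log units; beyond the scatter) but this is only a floor, because compound 2 stands at a limit of the assay rather than a number: the limit of > 50000 nM in this assay, at which 1 of the 4 values shown sits.

Going by these compounds, whether a methoxy group, an amine or a longer chain at this position would lower the number as phenyl does remains open.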